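The source may hold more compounds than are shown below. What is called first, only, known or untested is meant among the compounds shown, and "the series" means these compounds.

Compound 1 `Cc1cccc(/C(N)=N/NC(=S)N2CCSCC2)n1`: 81.6%
Compound 2 `Cc1cccc(/C(N)=N/NC(=S)N2CCOCC2)n1`: 82.4%
Compound 3 `Cc1cccc(/C(N)=N/NC(=S)N2CCCCC2)n1`: 85.4%

All three share one core and differ only in the saturated ring attached to the thiocarbonyl carbon. In a functional assay on HeLa cells (Homo sapiens) for cytotoxicity, read by MTT assay, with a stated time of 72 h, tested at 100 uM (a lower number here means less inhibition of growth, a higher number more inhibition of growth at the concentration tested), compound 3 sits at the high end of the three numbers, but only by a number 3.8 percentage points higher from compound 1 to compound 3 (within the scatter) and a number 3 percentage points higher from compound 2 to compound 3 (within the scatter), both within the scatter, so the three cannot truly be told apart. Compound 4 `Cc1cccc(/C(N)=N/NC(=S)N2CCCC2)n1` has not been measured; it carries pyrrolidin-1-yl in place of piperidin-1-yl on a thiocarbonyl carbon. The relevant comparisons are the earlier ring swaps at the same place, namely a number 0.8 percentage points higher from compound 1 to compound 2 (within the scatter), a number 3.8 percentage points higher from compound 1 to compound 3 (within the scatter) and a number 3 percentage points higher from compound 2 to compound 3 (within the scatter), none of them beyond the scatter. A further ring swap is therefore expected to bring no step beyond the scatter, a number 2.4 percentage points lower from compound 3 to compound 4 (within the scatter). Compound 4 is estimated at 83%, within a range from 72% to 92%.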

Compound 4, percent growth inhibition at one concentration: 80.1%
Compound 4: the middle estimate sits 2.9 percentage points above what was measured; low and high end bracket the measured number.
By their numbers in this assay, from the lowest: compounds 4, 1, 2 and 3 (each within the scatter of the next).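

In this assay, the five-membered pyrrolidin-1-yl in place of the six-membered piperidin-1-yl on a thiocarbonyl carbon gives (a number 5.3 percentage points lower from compound 3 to compound 4 (within the scatter)), so this change of ring size does not separate the two compounds. The same holds for the swaps from morpholin-4-yl (a number 2.3 percentage points lower from compound 2 to compound 4 (within the scatter)) and thiomorpholin-4-yl (a number 1.5 percentage points lower from compound 1 to compound 4 (within the scatter)). No available evidence bears on how these rings affect the cells. From the compounds shown here alone, whether an open-chain dimethylamino group or a piperazin-1-yl ring at this place would give a step beyond the scatter remains open.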